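The compounds below may be only part of what the source reports. "The series", "measured", "known", "first", "only" and "open" are said of these compounds alone.

Compound 2 `C#CCNC1CCc2c(SCc3ccc(Br)cc3)cccc21` gives 488 nM in an ADME assay on isolated protein for inhibition of Amine oxidase [flavin-containing] B (Homo sapiens) (on this read-out higher numbers stand for weaker inhibition and lower numbers for stronger inhibition), the lowest of the three numbers measured. The nearest of the others is compound 3 `C#CCNC1CCc2c(SCc3ccc(F)cc3F)cccc21`, which gives 1480 nM in this assay; the furthest is compound 1 `C#CCNC1CCc2c(SCc3cccc(F)c3)cccc21`, which gives 11600 nM. Going by the values given here, only one measured step can be read directly: a 24-fold lower number from compound 1 to compound 2 (1.38 log units; beyond the scatter). That step changes both the halogen and where it sits on the ring, so it shows that this part of the molecule matters a great deal, but it does not say how a single swap at one fixed place behaves.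

Compound 4 `C#CCNC1CCc2c(SCc3ccc(C)cc3)cccc21` differs from compound 2 by methyl in place of bromo on an aromatic carbon. Among the compounds with values here, no measured pair swaps a halogen for a methyl, so there is no direct guide. What leaves and what enters are each a single heavy atom, with no donors, no acceptors and no charge, sitting on the same aromatic carbon. On that basis the step expected in this assay, a 1.8-fold higher number from compound 2 to compound 4 (0.27 log units; within the scatter), is small, toward a somewhat higher number, and plausibly within the usual scatter of repeat measurements. Compound 4 is therefore estimated at 900 nM, with a likely range from 300 nM to 3000 nM.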

Compound 4, half-maximal inhibitory concentration: 320 nM
Compound 4: the middle estimate sits 2.8-fold (0.45 log units) above what was measured; low and high end bracket the measured number.
By their numbers in this assay, from the lowest: compounds 4 and 2 (each within the scatter of the next); then compound 3; then compound 1.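

In this assay, the new compound gives the first swap made at one fixed place on the ring, and the step, a 1.5-fold lower number from compound 2 to compound 4 (0.18 log units; within the scatter), lies within the scatter, so bromo and methyl on this aromatic carbon cannot be told apart. The earlier compounds could not show this, since their only step changed the halogen and its place together; here, compound 4 carries no halogen at all on its benzyl ring and still stands level with compound 2, so among these compounds a bromine is not needed at this place. The second step, a 36-fold lower number from compound 1 to compound 4 (1.56 log units; beyond the scatter), is large and beyond the scatter, which shows that the 3-fluorophenyl of compound 1 stands far from both the 4-bromophenyl and the 4-methylphenyl compounds, whichever of those two groups is compared with it.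

As far as these compounds go, how far this tolerance extends, for instance to a methoxy group, an amine or a carboxylic acid on this same aromatic carbon, stays open, as does how much of the large gap to compound 1 belongs to the place on the ring and how much to the group itself. Nothing available here offers an explanation for these numbers.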